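The source may report more compounds than this note shows. Statements on the series, on what has been measured and on what is new or still open speak of the compounds shown alone.

In a functional assay on V79-379A cells (Cricetulus griseus) for cytotoxicity, read by MTT assay, in the presence of a further agent that is not named here (a lower number here means a stronger inhibitor, a higher number a weaker inhibitor), compound 1 `COC1=CC(=O)c2c(c(CCl)cn2C)C1=O` gives 33000 nM as its half-maximal inhibitory concentration, and compound 3 `COC1=CC(=O)c2c(c(COc3c(Cl)cc(Cl)cc3Cl)cn2C)C1=O` gives 80 nM on the same scale. Compound 2 `COC1=CC(=O)c2c(c(COCc3ccccc3)c(C)n2C)C1=O` gives 410000 nM as the highest of the three numbers, beyond the scatter from both others, which makes compound 2 the weakest inhibitor so far.

The next compound is compound 4 `COC1=CC(=O)c2c(c(COc3ccccc3)c(C)n2C)C1=O`. Its difference from compound 2 is phenyl in place of benzyl on an oxygen on a saturated carbon in one place: phenyl in place of benzyl on an oxygen on a saturated carbon, or benzyloxy to phenoxy. Among the compounds with values here, no measured pair isolates this change. Within the data shown here, the only guide is compound 3, a substituted phenoxy compound, at 80 nM against the number of compound 2, and those two differ in more than this one place. A lower number beyond the scatter is therefore expected, though one far short of reaching compound 3. The estimated step is a 14-fold lower number from compound 2 to compound 4 (1.14 log units; beyond the scatter) toward stronger inhibition. For compound 4 the estimated value is 30000 nM with an expected range from 4000 nM to 200000 nM in this assay for now.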

Compound 4, half-maximal inhibitory concentration: 700 nM
Beside the measured number, compound 4's estimate is 43-fold (1.63 log units) above it; measured number outside the range, below it.
By their numbers in this assay, from the lowest: compound 3; then compound 4; then compound 1; then compound 2.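

In this assay, within the data shown here, the change from benzyloxy to phenoxy gives a 590-fold lower number from compound 2 to compound 4 (2.77 log units; beyond the scatter) and is the first comparison that isolates a single place. Among these compounds, the group on the oxygen on a saturated carbon therefore has a large influence on this read-out, which the earlier compounds could not show because they differ from one another in more than one place. Within this pair, the phenyl group gives the stronger inhibitor, and the step rests on this single pair alone.

On these data alone, it remains open whether a longer chain, such as phenethyl, on the same oxygen would continue or reverse this direction, and whether an amine in place of that oxygen would keep the strength of compound 4. As far as these compounds go, whether the same change holds on the core of compound 3 also remains open. Nothing measured here explains the size of the step.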